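Adding a second trifluoromethyl to the hydrazone aryl ring

The source may report more compounds than this note shows. Statements on the series, on what has been measured and on what is new or still open speak of the compounds shown alone.

Compound 1 `CN(C(=O)NC(=O)c1c(F)cccc1F)c1nc(C(F)(F)F)c(C(=O)N/N=C/c2cccc(C(F)(F)F)c2)s1` gives 27.6 ug/mL in a functional assay on A549 cells (Homo sapiens) for inhibition, read by MTT assay, with a stated time of 72 h (a lower number here means a stronger inhibitor, a higher number a weaker inhibitor), the highest of the three numbers measured. Compound 2 `CN(C(=O)NC(=O)c1ccc(C(F)(F)F)cc1)c1nc(C(F)(F)F)c(C(=O)N/N=C/c2cccc(C(F)(F)F)c2)s1` gives 6.66 ug/mL and compound 3 `CN(C(=O)NC(=O)c1ccc([N+](=O)[O-])cc1)c1nc(C(F)(F)F)c(C(=O)N/N=C/c2cccc(C(F)(F)F)c2)s1` gives 5.42 ug/mL; both differ from compound 1 only at the acyl aryl group, with a 4.1-fold lower number from compound 1 to compound 2 (0.62 log units; beyond the scatter) and a 5.1-fold lower number from compound 1 to compound 3 (0.71 log units; beyond the scatter). Compound 4 `CN(C(=O)NC(=O)c1c(F)cccc1F)c1nc(C(F)(F)F)c(C(=O)N/N=C/c2cc(C(F)(F)F)cc(C(F)(F)F)c2)s1` instead keeps that part unchanged and carries trifluoromethyl in place of hydrogen on an aromatic carbon, on the aryl ring of the hydrazone. Among the compounds with values here, no measured step touches this position, so the known steps offer no direct guide. With nothing to point either way, the estimated change is a 1.4-fold lower number from compound 1 to compound 4 (0.14 log units; within the scatter), and compound 4 is expected to give about 20 ug/mL, in a range from 8 ug/mL to 55 ug/mL.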

Compound 4, half-maximal inhibitory concentration: 17.3 ug/mL
For compound 4 the middle estimate is 1.2-fold (0.06 log units) above the measured one; low and high end bracket the measured number.
By their numbers in this assay, from the lowest: compounds 3 and 2 (each within the scatter of the next); then compounds 4 and 1 (each within the scatter of the next).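

Within the data shown here, until now only the acyl aryl group had changed, and this is the first reading at the aryl ring of the hydrazone. In this assay trifluoromethyl in place of hydrogen, meta to a trifluoromethyl group, gives a 1.6-fold lower number from compound 1 to compound 4 (0.20 log units; within the scatter) and so cannot be told apart from hydrogen here, unlike the acyl aryl changes in compounds 2 and 3, which gave steps beyond the scatter. No measurement at hand offers an explanation for this result.

As far as these compounds go, whether an amine or a carboxylic acid at this position would give a step beyond the scatter stays open. So does whether a second trifluoromethyl would give the same result with the 4-nitrophenyl group of compound 3.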